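Notes on the chloro to hydroxy step

This account rests on a few compounds, and the source may have more. Where it says the series, first, only, none or still open, it means among the compounds named here.

In an ADME assay on MCF-10A cells (Homo sapiens) for inhibition, with a stated time of 48 h (on this read-out higher numbers stand for weaker inhibition and lower numbers for stronger inhibition), compound 1 `O=C(Nc1ccc(Cl)cc1)N1CCC[C@H]1c1nc(-c2ccccc2Cl)no1` gives > 50000 nM, which is a limit of the assay. Compound 2 `O=C(Nc1ccc(Cl)cc1)N1CCC[C@H]1c1nc(-c2cccc(Cl)c2)no1` gives > 50000 nM, also a limit, so its position has no number. Within the data shown here, the only measured step is a step that the two limits leave unreadable from compound 1 to compound 2, and the series so far shows (the limit of > 50000 nM in this assay, at which 2 of the 2 values shown sit). Compound 3 `O=C(Nc1ccc(Cl)cc1)N1CCC[C@H]1c1nc(-c2cccc(O)c2)no1` carries hydroxy in place of chloro on an aromatic carbon. Among the measured compounds shown here, no measured step covers this change. Resting on compound 2 at > 50000 nM, a limit, no step beyond the scatter is expected in this assay. Compound 3 is expected at 50000 nM, with an estimated range of 20000 nM to 100000 nM. The estimated step is a number no higher from compound 2 to compound 3 (the limit leaves the size open).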

Compound 3, half-maximal inhibitory concentration: > 50000 nM
Compound 3: only a limit was reported (the forecaster's own chance of this, stated with the estimate: 75%); the middle value sits exactly at the limit.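

No step can be read among compound 1, compound 2 and compound 3, since all three stand at a limit: the limit of > 50000 nM in this assay, at which 3 of the 3 values shown sit.

The compounds shown leave open whether 3-chlorophenyl in place of 2-chlorophenyl or hydroxy in place of chloro changes anything in this assay at concentrations under that limit.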